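A few compounds are considered here, and "the series" means these few. Any claim that something is new, unique, unknown or untested is made for them only; others in the source may bear on it.

The measured compounds, all tested in a functional assay on A2780 cells (Homo sapiens) for antiproliferative activity, read by MTT assay, with a stated time of 48 h (a lower number here means a stronger inhibitor, a higher number a weaker inhibitor), are these:

Compound 1 `C=C(/C=C/c1ccc(OC)c(N)c1)c1cc(OC)c(OC)c(OC)c1` gives 582 nM.
Compound 2 `CC=C(/C=C/c1ccc(OC)c(N)c1)c1cc(OC)c(OC)c(OC)c1` gives 137 nM.
Compound 3 `C=C(/C(C)=C/c1ccc(OC)c(O)c1)c1cc(OC)c(OC)c(OC)c1` gives 64 nM.

Compounds 1 and 2 share a core and differ in one place: methyl in place of hydrogen on a double-bonded chain carbon bound to a double-bonded chain carbon. That change produced a 4.2-fold lower number from compound 1 to compound 2 (0.63 log units; beyond the scatter). Compound 3 has the lowest number of the three; its steps to compound 2 and to compound 1 both lie beyond the scatter, so among the measured compounds it is the most potent. The difference between the core of compound 1 and the core of compound 3 is not broken down here.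

Compound 4 `CC=C(/C(C)=C/c1ccc(OC)c(O)c1)c1cc(OC)c(OC)c(OC)c1` has not yet been measured. It differs from compound 3 as follows: methyl in place of hydrogen on a double-bonded chain carbon bound to a double-bonded chain carbon. Among the compounds with values here, this is the same kind of change as the one from compound 1 to compound 2, made at the same kind of place. Within the data shown here, the only precedent for it is that single step, which was modest and beyond the scatter, and compound 3 starts from a lower number than compound 1 did, so the account rests on one example applied to a different core. On that basis compound 4 is expected to show a step of a 2.1-fold lower number from compound 3 to compound 4 (0.33 log units; beyond the scatter) in this assay. The number expected for compound 4 in this assay is estimated at 30 nM, most likely between 10 nM and 100 nM.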

Compound 4, half-maximal inhibitory concentration: 505 nM
Beside the measured number, compound 4's estimate is 17-fold (1.23 log units) below it; measured number above the stated range.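

In this assay, the same single change, a methyl entering where a hydrogen stood, gave a 7.9-fold higher number from compound 3 to compound 4 (0.90 log units; beyond the scatter), so the direction seen on the core of compound 1 did not carry over to the core of compound 3. Set side by side, the two steps run in opposite directions and clearly differ: the same change on two cores in this assay, a 4.2-fold lower number (0.63 log units; beyond the scatter) from compound 1 to compound 2 and a 7.9-fold higher number (0.90 log units; beyond the scatter) from compound 3 to compound 4, 34-fold (1.53 log units) apart, beyond the scatter of two such steps This shows that, in these two pairs, the outcome of the change depends on the core that carries it, so a step measured on one core is not a safe guide to the other; it does not show which feature of the cores decides the direction, and two pairs give no rule for any further core.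

The compounds shown leave open how an ethyl group or a longer chain would behave on the same double-bonded chain carbon, and whether the number would keep rising or fall back with such a group. They also leave open which of the features that separate the two cores goes with the reversal, and whether a core carrying only some of those features would follow compound 2 or compound 4.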